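A few compounds are considered here, and "the series" means these few. Any claim that something is new, unique, unknown or untested is made for them only; others in the source may bear on it.

Three members of one polyene acid series have been tested so far. Compound 1 `C[C@H](/C=C/C=C/C=C/[C@H](O)CC(=O)O)[C@@H](O)[C@H](C)C[C@@H](C)[C@H](O)CC(=O)c1ccc(N)cc1` carries an unsubstituted amino group on its aromatic ring. Compound 2 `CNc1ccc(C(=O)C[C@@H](O)[C@H](C)C[C@@H](C)[C@H](O)[C@H](C)/C=C/C=C/C=C/[C@H](O)CC(=O)O)cc1` carries a methyl on that nitrogen, and compound 3 `CC(=O)Nc1ccc(C(=O)C[C@@H](O)[C@H](C)C[C@@H](C)[C@H](O)[C@H](C)/C=C/C=C/C=C/[C@H](O)CC(=O)O)cc1` carries an acetyl there. In a functional assay on SNU-638 cells (Homo sapiens) for cytotoxicity, read by sulforhodamine B assay, with a stated time of 72 h (on this read-out lower numbers stand for stronger inhibition and higher numbers for weaker inhibition), compound 1 gives > 10000 nM, which is a limit of the assay rather than a number. In this assay compound 2 likewise gives only the limit > 10000 nM. In this assay compound 3 also stops at the limit > 10000 nM. Compound 3 therefore stands at the same edge as the other two: the limit of > 10000 nM in this assay, at which 3 of the 3 values shown sit. The three steps among them, a step that the two limits leave unreadable from compound 1 to compound 2, a step that the two limits leave unreadable from compound 1 to compound 3 and a step that the two limits leave unreadable from compound 2 to compound 3, cannot be sized, since each runs from one limit to another.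

Compound 4 `C[C@H](/C=C/C=C/C=C/[C@H](O)CC(=O)O)[C@@H](O)[C@H](C)C[C@@H](C)[C@H](O)CC(=O)c1ccc(N[C@@H]2O[C@H](CO)[C@@H](O)[C@H](O)[C@H]2O)cc1` is not yet measured. It differs from compound 3 in that (3,4,5-trihydroxy-6-(hydroxymethyl)oxan-2-yl in place of acetyl on a nitrogen on an aromatic ring). The measured steps that touch the aromatic nitrogen all end at the limit, so they give no direction for this assay; they only show that none of the three groups on that nitrogen produced a readable number. The expected step that the limit leaves unreadable from compound 3 to compound 4 is therefore little more than a guess that compound 4 stays near the limit. Compound 4 is estimated at 12000 nM, with a range from 4000 nM to 40000 nM, and is most likely to return only another limit.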

Compound 4, half-maximal inhibitory concentration: > 10000 nM
Compound 4 gave a limit, no number (the forecaster's own chance of this, stated with the estimate: 80%); the middle value does not contradict the limit.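

Compound 4 gives only a limit in this assay, so none of its steps from compound 1, compound 2 or compound 3 can be read, and all the compounds now sit at one edge: the limit of > 10000 nM in this assay, at which 4 of the 4 values shown sit.

The compounds shown leave open how strongly any of them acts in this assay, and whether the group on the aromatic nitrogen matters at all.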